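The source may hold more compounds than are shown below. What is called first, only, known or untested is meant among the compounds shown, and "the series" means these compounds.

In a functional assay on RPMI-8226 cells (Homo sapiens) for inhibition, read by sulforhodamine B assay, with a stated time of 48 h (a lower number here means that less compound is tolerated, a higher number that more compound is tolerated), compound 1 `O=C(Nc1cccc(-n2cc(-c3ccncc3)c(-c3ccc(Cl)c(O)c3)n2)c1)Nc1cccc(C(F)(F)F)c1` gives only a limit, > 32500 nM. Compound 2 `COc1cc(-c2nn(-c3cccc(NC(=O)Nc4cc(C(F)(F)F)cc(C(F)(F)F)c4)c3)cc2-c2ccncc2)ccc1Cl` likewise stops at a limit, > 50000 nM. Compound 3 `COc1cc(-c2nn(-c3cccc(NC(=O)c4cccc(C(F)(F)F)c4)c3)cc2-c2ccncc2)ccc1Cl` also stops at a limit, > 50000 nM. Among the compounds with values here, one of the three values sits at the limit of > 32500 nM in this assay, at which 1 of the 3 values shown sits, and two sit at the limit of > 50000 nM in this assay, at which 2 of the 3 values shown sit; no numbered value is on hand for this core, so no step between measured compounds can be sized. Compound 4 `O=C(Nc1cccc(-n2cc(-c3ccncc3)c(-c3ccc(Cl)c(O)c3)n2)c1)Nc1ccc(Cl)c(Cl)c1` is not yet measured; it differs from compound 1 by 3,4-dichlorophenyl in place of 3-(trifluoromethyl)phenyl on an amide-type nitrogen. With every value on this core resting at a limit, no shift beyond the scatter is expected, and the step that the limit leaves unreadable from compound 1 to compound 4 is estimated to stay within it. Compound 4 is expected to give 40000 nM, with a range of 12000 nM to 100000 nM, most probably reported again only as a limit.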

Compound 4, concentration lethal to 50% of the cells: > 32500 nM
Compound 4: a limit, no number; the forecaster's own chance of this, stated with the estimate: 75%; the middle value is on the limit's open side.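

Compound 1 and compound 4 both stop at a limit in this assay, and the step between them cannot be read. The compounds shown leave open whether any change on the shared core yields a numbered value.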